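Cyclohexyl for cyclopropyl in the whole-animal antagonist series

A few compounds are considered here, and "the series" means these few. Any claim that something is new, unique, unknown or untested is made for them only; others in the source may bear on it.

Compound 1 `COc1cc(N)c(Cl)cc1NC(=O)C1CCN(CC2CC2)CC1` gives in a functional assay on the whole organism for antagonist activity, with Mus musculus as the target (on this read-out lower numbers stand for an effect already at smaller amounts and higher numbers for an effect only at larger amounts of compound), only an assay limit, > 10 mg/kg.
Compound 2 `CCN1CCC(C(=O)Nc2cc(Cl)c(N)cc2OC)CC1` gives in this assay only an assay limit, > 10 mg/kg.

Compound 1 thus stands at a limit of this assay, not at a number. Among the compounds with values here, the one measured step at the same place, a step that the two limits leave unreadable from compound 1 to compound 2, is hidden by the two limits; the limit of > 10 mg/kg in this assay, at which 2 of the 2 values shown sit, shows both values sitting there. Compound 3 `COc1cc(N)c(Cl)cc1NC(=O)C1CCN(CC2CCCCC2)CC1` differs from compound 1 by cyclohexyl in place of cyclopropyl on a saturated chain carbon bound to an amine nitrogen in a ring. Within the data shown here, no measured step therefore gives a direction or size for this change, and no step beyond the scatter can be expected from it.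

Compound 3 is estimated at 15 mg/kg, with a range of 4 mg/kg to 60 mg/kg, most likely again reported as a limit. The step that the limit leaves unreadable from compound 1 to compound 3 is expected to be small.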

Compound 3, dose for half-maximal effect: 2.9 mg/kg
Compound 3: middle estimate off by 5.2-fold (0.71 log units), on the high side; the measured number lies below the stated range.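

In this assay, within the data shown here, this position is not silent: cyclohexyl in place of cyclopropyl gives the first readable step here (an at least 3.4-fold lower number from compound 1 to compound 3 (0.53 log units; beyond the scatter)), and cyclohexyl in place of methyl does the same (an at least 3.4-fold lower number from compound 2 to compound 3 (0.53 log units; beyond the scatter)). Going by these compounds, both steps start from a limit, so their full size stays unknown. The step between compound 1 and compound 2 cannot be read: the limit of > 10 mg/kg in this assay, at which 2 of the 3 values shown sit.

On these data alone, whether the drop in dose follows ring size or simply the number of carbons stays open. Cyclopentyl, phenyl or an open hexyl chain at this place would separate these readings.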